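The source may report more compounds than this note shows. Statements on the series, on what has been measured and on what is new or still open speak of the compounds shown alone.

Among the compounds with values here, compound 1 `CC(C)(C)n1ncc(OCc2nnc(-c3ccccc3Cl)o2)c(Cl)c1=O` carries a 2-chlorophenyl on the shared core; in a functional assay on the whole organism for inhibition, with Mythimna separata as the target, with a stated time of 5 days (a higher number here means that more compound is needed for the effect, a lower number that less compound is needed), compound 1 gives 61200 nM, the only resolved number in the set. Compound 2 `COc1c(F)c(F)cc(-c2nnc(COc3cnn(C(C)(C)C)c(=O)c3Cl)o2)c1F` reaches only a limit of the assay, > 299000 nM. Compound 3 `CC(C)(C)n1ncc(OCc2nnc(-c3cc(F)c(Cl)c([N+](=O)[O-])c3Cl)o2)c(Cl)c1=O` likewise sits at a limit, > 299000 nM. Two of the three values thus rest at the limit of > 299000 nM in this assay, at which 2 of the 3 values shown sit. Compound 1 therefore stands alone as the single numbered point. Compound 4 `CC(C)(C)n1ncc(OCc2nnc(-c3cccs3)o2)c(Cl)c1=O` differs from compound 1 by thiophen-2-yl in place of 2-chlorophenyl on an aromatic carbon. Within the data shown here, no step between measured compounds is available to anchor this change, so the size is uncertain. Compound 4 is expected at 100000 nM, with a range of 30000 nM to 299000 nM. The expected step of a 1.6-fold higher number from compound 1 to compound 4 (0.21 log units; within the scatter) is a modest loss, with a fair chance that this assay reports only a limit.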

Compound 4, half-maximal effective concentration: > 299000 nM
Compound 4 gave a limit, no number; the forecaster's own chance of this, stated with the estimate: 35%; middle value at least 2.9-fold (0.47 log units) away from the limit.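

Thiophen-2-yl in place of 2-chlorophenyl, on an aromatic carbon of the five-membered aromatic ring with 2 nitrogen and 1 oxygen, gives the only step in the series in this assay: an at least 4.8-fold higher number from compound 1 to compound 4 (0.68 log units; beyond the scatter). Within the data shown here, this step shows that the result at this position depends on the group carried there, and 2-chlorophenyl remains the only group with a resolved number. The step gives only a lower bound on the size of the change because the value of compound 4 is a limit: the limit of > 299000 nM in this assay, at which 3 of the 4 values shown sit.

The step swaps the ring and removes the chlorine together, so the two changes stay unseparated. As far as these compounds go, whether unsubstituted phenyl or pyridin-2-yl at this position would give a resolved number remains open.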